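From 4-(trifluoromethyl)phenyl to pyrimidin-2-yl: an expected small step

A few compounds are considered here, and "the series" means these few. Any claim that something is new, unique, unknown or untested is made for them only; others in the source may bear on it.

In a functional assay on MCF7 cells (Homo sapiens) for antiproliferative activity, read by MTT assay, with a stated time of 72 h (a higher number here means a weaker inhibitor, a lower number a stronger inhibitor), three compounds sharing one core have been measured:

Compound 1 `Nc1nc(N)c2cc(CSC(=S)N3CCN(c4ccccc4F)CC3)ccc2n1` gives 4840 nM
Compound 2 `Nc1nc(N)c2cc(CSC(=S)N3CCN(c4ccccc4[N+](=O)[O-])CC3)ccc2n1` gives 4350 nM
Compound 3 `Nc1nc(N)c2cc(CSC(=S)N3CCN(c4ccc(C(F)(F)F)cc4)CC3)ccc2n1` gives 7400 nM

Compound 3 cannot be told apart from the other two on these numbers (a 1.5-fold higher number from compound 1 to compound 3 (0.18 log units; within the scatter); a 1.7-fold higher number from compound 2 to compound 3 (0.23 log units; within the scatter)). The next compound, compound 4 `Nc1nc(N)c2cc(CSC(=S)N3CCN(c4ncccn4)CC3)ccc2n1`, carries pyrimidin-2-yl in place of 4-(trifluoromethyl)phenyl on an amine nitrogen in a ring.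

For the measured compounds named here, the steps that bear on this change are the two just given, which exchange the aromatic group on that same nitrogen, and the exchange of fluoro for nitro on the aromatic carbon (a 1.1-fold lower number from compound 1 to compound 2 (0.05 log units; within the scatter)). None of the three leaves the scatter. Going by the values given here, still, no measured compound has a ring with hetero atoms at this place, so the data cover the new group only indirectly, and the range is kept wide. With a step this small (a 1.7-fold higher number from compound 2 to compound 3 (0.23 log units; within the scatter)), no step beyond the scatter is expected in this assay, in either direction. The estimated step is a 1.3-fold lower number from compound 3 to compound 4 (0.13 log units; within the scatter) and remains an expectation only. Compound 4 is estimated at 5500 nM (expected range 2000 nM to 15000 nM).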

Compound 4, half-maximal inhibitory concentration: 4190 nM
Compound 4: the middle estimate sits 1.3-fold (0.12 log units) above what was measured; the range from low to high includes it.
By their numbers in this assay, from the lowest: compounds 4, 2, 1 and 3 (each within the scatter of the next).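

In this assay, the first ring with hetero atoms on this amine nitrogen leaves the number within the scatter of all three compounds with a carbon-only ring (a 1.8-fold lower number from compound 3 to compound 4 (0.25 log units; within the scatter); a 1.0-fold lower number from compound 2 to compound 4 (0.02 log units; within the scatter); a 1.2-fold lower number from compound 1 to compound 4 (0.06 log units; within the scatter)). The change takes the group from 10 heavy atoms to 6 and from 0 hydrogen-bond acceptors to 2, yet none of these steps can be told apart from repeat variation, so the four compounds cannot be ranked and this position shows no dependence on the kind of six-membered aromatic ring tested so far. No supporting evidence bears on why these values stay so close.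

Every group shown here is a six-membered aromatic ring placed directly on the nitrogen, so it remains open whether a benzyl group, a simple methyl, an acetyl group or a five-membered ring such as thiazol-2-yl would move the number beyond the scatter. On these data alone, it also remains open whether pyridin-2-yl, with a single ring nitrogen, or a carboxylic acid on the aromatic ring would behave like pyrimidin-2-yl in this cell assay.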